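Methyl on the benzyl ring of a hydroxamic acid series

The source may report more compounds than this note shows. Statements on the series, on what has been measured and on what is new or still open speak of the compounds shown alone.

Compound 1 `O=C(/C=C/c1ccc(OCc2nc(C3CCN(Cc4ccccc4)CC3)no2)cc1)NO` is the starting point of this small set. In an assay on isolated protein for inhibition of protein deacetylase HDAC6 (Homo sapiens), read by fluorescence, with a stated time of 1 h, tested at 100 nM (a lower number here means less inhibition, a higher number more inhibition at the concentration tested (going by the name of the read-out)), compound 1 gives 71%. Compound 2 `Cc1cccc(CN2CCC(c3noc(COc4ccc(/C=C/C(=O)NO)cc4)n3)CC2)c1` differs from it only by methyl in place of hydrogen on an aromatic carbon, and in this assay compound 2 gives 73%, so the step of a number 2 percentage points higher from compound 1 to compound 2 (within the scatter) is small. Compound 3 `O=C(CCc1ccc(OCc2nc(C3CCN(Cc4ccccc4)CC3)no2)cc1)NO` shares the benzyl piperidine part with compound 1 but carries a different core: the difference is 2-(hydroxycarbamoyl)ethyl in place of 2-(hydroxycarbamoyl)ethenyl on an aromatic carbon. In this assay compound 3 gives 22%, and the step of a number 49 percentage points lower from compound 1 to compound 3 (beyond the scatter) is by far the largest in the set.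

Compound 4 `Cc1ccc(CN2CCC(c3noc(COc4ccc(CCC(=O)NO)cc4)n3)CC2)cc1` has not been measured. It is made from compound 3 by methyl in place of hydrogen on an aromatic carbon. Within the data shown here, this is the same kind of change as the one from compound 1 to compound 2, but not the same: in compound 2 the methyl sits meta to a large group, whereas in compound 4 it sits para to a large group. The expected step of a number 2 percentage points higher from compound 3 to compound 4 (within the scatter) is set beside the measured step because a number 2 percentage points higher from compound 1 to compound 2 (within the scatter) stayed within the scatter and the change is of the same kind. Accordingly, compound 4 is estimated to give 24% in this assay, with a plausible range from 10% to 40%.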

Compound 4, a percentage reported as inhibition, at one concentration (the size of the read-out at that concentration, not a potency): 28%
Estimate against measurement, compound 4: 4 percentage points below; low and high end bracket the measured number.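

In this assay the methyl gives a number 6 percentage points higher from compound 3 to compound 4 (within the scatter), so on the core carrying 2-(hydroxycarbamoyl)ethyl, as on the core carrying 2-(hydroxycarbamoyl)ethenyl, this small addition to the benzyl ring cannot be told apart from the scatter of repeated measurements. The two cores give steps that agree: the same change on two cores in this assay, a number 2 percentage points higher (within the scatter) from compound 1 to compound 2 and a number 6 percentage points higher (within the scatter) from compound 3 to compound 4, 4 percentage points apart, within the scatter of two such steps. This does not show that a methyl is without any effect or that the change carries over exactly, since both steps are small, each rests on one pair of compounds read at a single concentration, and the methyl does not stand at the same place in the two pairs, being para to a large group in compound 4 but not in compound 2.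

The compounds shown leave open whether a methyl at one and the same place on the ring would behave alike on both cores, and whether a larger or different group there, such as methoxy, chlorine or an amine, would also leave the number unchanged within the scatter. They also leave open whether a longer chain leading to the hydroxamic acid would change the picture on either core.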